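A few compounds are considered here, and "the series" means these few. Any claim that something is new, unique, unknown or untested is made for them only; others in the source may bear on it.

Measured so far in a functional assay on A549 cells (Homo sapiens) for cytotoxicity, read by MTT assay, with a stated time of 48 h; on this read-out higher numbers stand for weaker inhibition and lower numbers for stronger inhibition:
Compound 1 `Cc1ccc(C2=NO[C@@H]3[C@H](CO)C[C@H](CO)[C@H]23)cc1`: > 50 ug/mL
Compound 2 `OC[C@@H]1C[C@H](CO)[C@@H]2C(c3ccc(Br)cc3)=NO[C@H]12`: > 50 ug/mL
Compound 3 `COc1ccc(C2=NO[C@@H]3[C@H](CO)C[C@H](CO)[C@H]23)cc1`: 36.6 ug/mL

Going by the values given here, compound 3, at 36.6 ug/mL, holds the only true number here. The other two entries are limits, not numbers, which leaves (the limit of > 50 ug/mL in this assay, at which 2 of the 3 values shown sit).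

The next compound is compound 4 `OC[C@@H]1C[C@H](CO)[C@@H]2C(c3ccc(F)cc3)=NO[C@H]12`, with fluoro in place of methoxy on an aromatic carbon.

Among the compounds with values here, two measured steps bear on this change, and both bring methoxy in at this kind of carbon: an at least 1.3-fold lower number from compound 1 to compound 3 (0.13 log units; that floor lies within the scatter), and an at least 1.3-fold lower number from compound 2 to compound 3 (0.13 log units; that floor lies within the scatter). Neither shows a firm difference. The remaining step, a step that the two limits leave unreadable from compound 1 to compound 2, adds nothing.

Bromo is the only other halogen measured here, and compound 2 carries it. Compound 2 stands at a limit, > 50 ug/mL. Compound 4 is therefore expected to lose a little inhibition in this assay, and a report of only the limit would be no surprise.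

The expected change is a 1.4-fold higher number from compound 3 to compound 4 (0.14 log units; within the scatter), towards a higher number.

For compound 4 the estimated value is 50 ug/mL, with an expected range of 30 ug/mL to 90 ug/mL.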

Compound 4, half-maximal inhibitory concentration: 31.1 ug/mL
For compound 4 the middle estimate is 1.6-fold (0.21 log units) above the measured one; the measured number falls inside the stated range.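

In this assay, fluoro and methoxy on this aromatic carbon cannot be told apart, with a 1.2-fold lower number from compound 3 to compound 4 (0.07 log units; within the scatter). Fluoro is thus the second group at this place, after methoxy, to give a true number rather than a limit. Compared with the bromo and methyl groups, the result gives only an at least 1.6-fold lower number from compound 2 to compound 4 (0.20 log units; that floor lies within the scatter) and an at least 1.6-fold lower number from compound 1 to compound 4 (0.20 log units; that floor lies within the scatter), so no firm gap from either compound is shown, because each of those two compounds is held at a limit: the limit of > 50 ug/mL in this assay, at which 2 of the 4 values shown sit.

From the compounds shown here alone, what an amine or a carboxylic acid would do on this aromatic carbon stays open. All the compounds shown also keep the same core, so the effect of any change elsewhere in the molecule remains unknown.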